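The compounds below may be only part of what the source reports. "The series", "measured", "known", "first", "only" and "open" are said of these compounds alone.

Measured in a functional assay on PC-3 cells (Homo sapiens) for cytotoxicity, read by MTT assay, with a stated time of 72 h (on this read-out lower numbers stand for stronger inhibition and higher numbers for weaker inhibition), each entry being a limit of the assay and not a number:

Compound 1 `CNC(=O)c1cc(Oc2ccc(NC(=O)c3cc(-c4ccc(C)cc4)ncn3)cc2)ccn1`: > 100000 nM
Compound 2 `CNC(=O)c1cc(Oc2ccc(NC(=O)c3cc(-c4ccc(Br)cc4)ncn3)cc2)ccn1`: > 100000 nM
Compound 3 `CNC(=O)c1cc(Oc2ccc(NC(=O)c3cc(-c4ccc(Cl)cc4)ncn3)cc2)ccn1`: > 100000 nM

Compound 3 gives no number in this assay. Its entry is a limit, and compounds 1 and 2 share it, so the series offers only (the limit of > 100000 nM in this assay, at which 3 of the 3 values shown sit).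

Compound 4 `CNC(=O)c1cc(Oc2ccc(NC(=O)c3cc(-c4ccccc4)ncn3)cc2)ccn1` differs from compound 3 at one place, (hydrogen in place of chloro on an aromatic carbon). This is hydrogen in place of chloro on an aromatic carbon, the same difference reading 4-chlorophenyl to phenyl.

Within the data shown here, three measured steps concern that same carbon: a step that the two limits leave unreadable from compound 1 to compound 3, a step that the two limits leave unreadable from compound 2 to compound 3 and a step that the two limits leave unreadable from compound 1 to compound 2. None of them has a readable size, so they give no measured effect of the group at this carbon, and none of them involves hydrogen. Among the measured compounds shown here, still, methyl, bromo and chloro all leave the compound at the same limit, with no compound going against this. The expectation is therefore no change beyond the scatter and no particular direction, with a limit again the likeliest report.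

The expected step is a number no higher from compound 3 to compound 4 (the limit leaves the size open).

For compound 4 the estimated value is 100000 nM, with an expected range from 30000 nM to 200000 nM.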

Compound 4, half-maximal inhibitory concentration: 44200 nM
Compound 4: middle estimate off by 2.3-fold (0.35 log units), on the high side; measured number inside the range.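

In this assay, among these compounds, hydrogen on this aromatic carbon yields the first readable number, with compound 4, the phenyl member, at 44200 nM. Hydrogen in place of chloro gives an at least 2.2-fold lower number from compound 3 to compound 4 (0.35 log units; beyond the scatter), hydrogen in place of bromo gives an at least 2.2-fold lower number from compound 2 to compound 4 (0.35 log units; beyond the scatter), and hydrogen in place of methyl gives an at least 2.2-fold lower number from compound 1 to compound 4 (0.35 log units; beyond the scatter), while the steps among compounds 1, 2 and 3 cannot be read. The position therefore does respond to a change, but the result separates only hydrogen from the other three groups, which still share one entry: the limit of > 100000 nM in this assay, at which 3 of the 4 values shown sit.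

Each of the three sizes is a minimum, so the compounds shown do not tell how far methyl, bromo or chloro actually lies from hydrogen, nor how those three groups rank against one another. As far as these compounds go, it also remains open whether a group such as fluoro, methoxy or an amine on this carbon would stay near the number of compound 4 or return to the limit.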